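Swapping a Methoxy Chain for 1,3-Dimethylbutyl

The source may report more compounds than this note shows. Statements on the series, on what has been measured and on what is new or still open speak of the compounds shown alone.

This step starts from compound 3 `COC(C)(C)CCn1nc(-c2cccs2)c(O)c(C2=NS(=O)(=O)c3cc(NS(C)(=O)=O)ccc3N2)c1=O`, tested in an ADME assay on Huh-7 cells (Homo sapiens) for cytotoxicity, with a stated time of 72 h; on this read-out higher numbers stand for lower toxicity in this test and lower numbers for higher toxicity in this test. Compound 3 gives > 33000 nM, which is a limit of the assay and not a number. Compound 1 `CS(=O)(=O)Nc1ccc2c(c1)S(=O)(=O)N=C(c1c(O)c(-c3cccs3)nn(CCC3CC3)c1=O)N2` gives > 33000 nM, also a limit. Compound 2 `CS(=O)(=O)Nc1ccc2c(c1)S(=O)(=O)N=C(c1c(O)c(-c3cccs3)nn(CC3CCC3)c1=O)N2` gives > 1000 nM, again a limit.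

Compound 4 `CC(C)CC(C)n1nc(-c2cccs2)c(O)c(C2=NS(=O)(=O)c3cc(NS(C)(=O)=O)ccc3N2)c1=O` carries 1,3-dimethylbutyl in place of 3-methoxy-3-methylbutyl on an aromatic nitrogen. The measured changes to this side chain offer no size to build on. They are a step that the two limits leave unreadable from compound 1 to compound 2, a step that the two limits leave unreadable from compound 1 to compound 3 and a step that the two limits leave unreadable from compound 2 to compound 3.

With no readable step available, no change beyond the usual scatter is expected in this assay. That expectation rests on compound 3, whose > 33000 nM is a limit. The expected size is a number no higher from compound 3 to compound 4 (the limit leaves the size open). Compound 4 is estimated at 33000 nM, with an expected range of 10000 nM to 60000 nM.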

Compound 4, half-maximal cytotoxic concentration: > 33000 nM
Compound 4 gave a limit, no number; the forecaster's own chance of this, stated with the estimate: 75%; the middle value lies on the limit itself.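

In this assay compound 4 gives > 33000 nM, which is a limit of the assay and not a number. No size can be read for the steps to compound 4 from compound 1, compound 2 or compound 3. The compounds shown leave open whether these four side chains on the aromatic nitrogen differ at all in this assay.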